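The source may report more compounds than this note shows. Statements on the series, on what has been measured and on what is new or still open speak of the compounds shown alone.

Compound 1 `CC(C)CCn1cnc2c(NCc3cccc(Cl)c3)nc(N[C@H]3CC[C@H](N)CC3)nc21`: 1330 nM
Compound 2 `CC(C)CCn1cnc2c(Nc3cccc(O)c3)nc(N[C@H]3CC[C@H](N)CC3)nc21`: 60 nM
Compound 3 `CC(C)CCn1cnc2c(Nc3ccccc3)nc(N[C@H]3CC[C@H](N)CC3)nc21`: 10 nM

In a functional assay on EOL1 cells (Homo sapiens) for inhibition, read by fluorescence, with a stated time of 72 h (on this read-out higher numbers stand for weaker inhibition of growth and lower numbers for stronger inhibition of growth), compound 3 gives the lowest number of the three. Compound 2 stands nearest to it, with a 6.0-fold lower number from compound 2 to compound 3 (0.78 log units; beyond the scatter), and compound 1 furthest, with a 130-fold lower number from compound 1 to compound 3 (2.12 log units; beyond the scatter). Both of those steps, and also a 22-fold lower number from compound 1 to compound 2 (1.35 log units; beyond the scatter), changed the group on a nitrogen on an aromatic ring; the saturated chain on the other nitrogen of the shared core stayed the same in all three compounds.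

Compound 4 `CCCCn1cnc2c(Nc3ccccc3)nc(N[C@H]3CC[C@H](N)CC3)nc21` keeps the phenyl of compound 3 and alters only that chain: hydrogen in place of methyl on a saturated chain carbon bound to two saturated chain carbons. Among the compounds with values here, none of the measured steps touches this part of the molecule, so nothing among the measured compounds shows how the growth inhibition answers to a change here. Within the data shown here, with no step to lean on, the expectation is that compound 4 stays close to compound 3, within or only slightly beyond the usual scatter, most likely with a somewhat higher number. The estimated step is a 1.5-fold higher number from compound 3 to compound 4 (0.18 log units; within the scatter). Compound 4 is therefore expected to give about 15 nM in this assay, with a range from 5 nM to 50 nM.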

Compound 4, concentration for 50% growth inhibition: 20 nM
Compound 4: the middle estimate sits 1.3-fold (0.12 log units) below what was measured; measured number inside the range.
By their numbers in this assay, from the lowest: compounds 3 and 4 (each within the scatter of the next); then compound 2; then compound 1.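

The chain on the other nitrogen of the shared core now gets its first test: isopentyl in compound 3 becomes butyl in compound 4, and in this assay this gives a 2.0-fold higher number from compound 3 to compound 4 (0.30 log units; within the scatter). For this one pair, then, removing the methyl leaves growth inhibition within the scatter of repeated measurements, whereas each earlier change to the group on the nitrogen on the aromatic ring gave a step beyond the scatter. Nothing available here accounts for this result, so it stands as an observation only.

As far as these compounds go, this single pair says little about the chain as a whole, so it remains open how a shorter chain such as ethyl, a longer chain such as hexyl, or a chain ending in an amine or a carboxylic acid would behave at this position. From the compounds shown here alone, it is also open whether the same swap from isopentyl to butyl would give a similarly small step with the 3-hydroxyphenyl of compound 2 or the 3-chlorobenzyl of compound 1 in place of the phenyl.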